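The source may hold more compounds than are shown below. What is called first, only, known or untested is meant among the compounds shown, and "the series" means these compounds.

Measured in an in vitro ADME assay on microsomes from liver (Homo sapiens) for metabolic stability, read by LC-MS; on this read-out higher numbers stand for a longer-lived compound and lower numbers for a shorter-lived compound:
- compound 1 `CN/C(=N\C1=NC(=O)C(=O)N1C(C)C)Nc1ccc(Cl)c(Cl)c1`: > 1 h (a limit)
- compound 2 `CC(C)N/C(=N\C1=NC(=O)C(=O)N1C(C)C)Nc1ccc(Cl)c(Cl)c1`: > 1 h (a limit)
- compound 3 `CC(C)N1C(=O)C(=O)N=C1/N=C(\NCc1ccccc1)Nc1ccc(Cl)c(Cl)c1`: > 1 h (a limit)

Compound 3 stands at > 1 h, which is a limit and not a number. Going by the values given here, the same holds across the set, with the limit of > 1 h in this assay, at which 3 of the 3 values shown sit, as the only information available, so no compound can be ranked against another.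

The next compound is compound 4 `CC(C)N1C(=O)C(=O)N=C1/N=C(\NCCCCN1CCCC1)Nc1ccc(Cl)c(Cl)c1`, which differs from compound 3 by 3-(pyrrolidin-1-yl)propyl in place of phenyl on a saturated chain carbon bound to an amine nitrogen. In words, this is 3-(pyrrolidin-1-yl)propyl in place of phenyl on a saturated chain carbon bound to an amine nitrogen. Cut one bond further out, it reads benzyl to 4-(pyrrolidin-1-yl)butyl.

The closest measured change is a step that the two limits leave unreadable from compound 1 to compound 3, at the same place. Also relevant are a step that the two limits leave unreadable from compound 2 to compound 3 and a step that the two limits leave unreadable from compound 1 to compound 2, both on an amine nitrogen. Among the compounds with values here, none of the three gives a size or a direction, and the entering group has no counterpart among the measured compounds.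

The expectation is therefore a step that the limit leaves unreadable from compound 3 to compound 4, with no step beyond the usual scatter expected and no direction assigned. Another result reported only as a limit is also expected to be more likely than not. In this assay the expected value for compound 4 is 1.2 h, with an estimated range from 0.5 h to 3 h around it.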

Compound 4, half-life: > 1 h
Compound 4: no number, only a limit; the forecaster's own chance of this, stated with the estimate: 65%; the middle value is on the limit's open side.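

In this assay compound 4 gives > 1 h as a limit, not a number. No new step can be read between compound 4 and compounds 1, 2 or 3, and the whole set rests on one limit: the limit of > 1 h in this assay, at which 4 of the 4 values shown sit.

The compounds shown leave open how long each one actually lasts, and whether any of the changes on the amine nitrogen alters that half-life.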